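The compounds below may be only part of what the source reports. "The series", "measured", "known", "first", "only" and "open" are said of these compounds alone.

Two compounds share one core and differ only in the group carried on the aromatic nitrogen. Compound 1 `COc1ccc(/C=C\C(=O)O)c(OCc2cn(-c3ccc(NC(=O)c4ccccc4)cc3)nn2)c1CC=C(C)C` in a functional assay on A-431 cells (Homo sapiens) for cytotoxicity, read by MTT assay, with a stated time of 24 h (on this read-out higher numbers stand for weaker inhibition and lower numbers for stronger inhibition), gives 21200 nM. Compound 2 `COc1ccc(/C=C\C(=O)O)c(OCc2cn(-c3cccc(C#N)c3)nn2)c1CC=C(C)C` in this assay gives 22900 nM, a number that sits within the scatter of compound 1. Compound 3 `COc1ccc(/C=C\C(=O)O)c(OCc2cn(-c3nc4ccccc4s3)nn2)c1CC=C(C)C` has not yet been measured in this assay; it differs from compound 2 by 1,3-benzothiazol-2-yl in place of 3-cyanophenyl on an aromatic nitrogen. Since the two measured groups give numbers within the scatter of each other, no step beyond the scatter is expected for compound 3 in this assay, which means an expected step of a 1.2-fold lower number from compound 2 to compound 3 (0.08 log units; within the scatter). Compound 3 is therefore estimated at 19000 nM, within 8000 nM to 42000 nM.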

Compound 3, half-maximal inhibitory concentration: 20800 nM
Compound 3: middle estimate off by 1.1-fold (0.04 log units), on the low side; the range from low to high includes it.
By their numbers in this assay, from the lowest: compounds 3, 1 and 2 (each within the scatter of the next).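

Replacing 3-cyanophenyl with 1,3-benzothiazol-2-yl gives a 1.1-fold lower number from compound 2 to compound 3 (0.04 log units; within the scatter) in this assay. Until now, this place on the aromatic nitrogen had carried only a six-membered aromatic ring of carbon, and a group with a five-membered aromatic ring holding 2 hetero atoms, one of them sulfur, leaves the number within the scatter. Nothing measured here offers an explanation for this result. On these data alone, whether an aminoethyl chain or a plain methyl group at this place would give a step beyond the scatter remains open.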